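This account rests on a few compounds, and the source may have more. Where it says the series, first, only, none or still open, it means among the compounds named here.

Compound 1 `COc1ccc(-c2cc(=O)c3c(OC)cc(OC)cc3n2C)cc1` is the reference point of this small set. In a functional assay on KOPN-8 cells (Homo sapiens) for antiproliferative activity, with a stated time of 72 h (a higher number here means that more compound is needed for the effect, a lower number that less compound is needed), compound 1 gives 30000 nM. Compound 2 `COc1ccc(-c2cc(=O)c3c(OC)cc(OC)cc3n2S(=O)(=O)c2ccc(C)c([N+](=O)[O-])c2)cc1` carries a 4-methyl-3-nitrophenyl group on a sulfonyl sulfur attached to the aromatic nitrogen. In this assay compound 2 reaches only a limit of the assay, > 51700 nM. Compound 3 `COc1ccc(-c2cc(=O)c3c(OC)cc(OC)cc3n2S(=O)(=O)c2cccc(Br)c2)cc1` carries a 3-bromophenyl group on that sulfonyl sulfur. In this assay compound 3 likewise reaches only a limit, > 58600 nM. Compound 3 therefore stands at a limit rather than at a number, and one further value in the set, that of compound 2, is a limit as well. The step of an at least 1.9-fold higher number from compound 1 to compound 3 (0.29 log units; that floor lies within the scatter) is bounded on one side only. The step that the two limits leave unreadable from compound 2 to compound 3 cannot be read, because both of its ends are limits the limit of > 51700 nM in this assay, at which 1 of the 3 values shown sits, and (the limit of > 58600 nM in this assay, at which 1 of the 3 values shown sits). Compound 4 `COc1ccc(-c2cc(=O)c3c(OC)cc(OC)cc3n2S(=O)(=O)c2ccc(Br)cc2)cc1` differs from compound 3 by 4-bromophenyl in place of 3-bromophenyl on a sulfonyl sulfur. Within the data shown here, the only measured step that concerns a change of the aryl group on the sulfonyl sulfur is a step that the two limits leave unreadable from compound 2 to compound 3, and it yields no readable size, while an at least 1.9-fold higher number from compound 1 to compound 3 (0.29 log units; that floor lies within the scatter) shows only that both sulfonyl compounds sit at or beyond the upper edge of this assay. Compound 4 is therefore expected to remain at that edge, and the step that the limit leaves unreadable from compound 3 to compound 4 is estimated to lie within the scatter. The estimate for compound 4 is 60000 nM, with a range from 20000 nM to 150000 nM.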

Compound 4, half-maximal effective concentration: > 86200 nM
Compound 4 ended at the assay's limit; the forecaster's own chance of this, stated with the estimate: 70%; middle value at least 1.4-fold (0.15 log units) away from the limit.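

In this assay compound 4 gives > 86200 nM, which is a limit of the assay and not a number. All steps among the three sulfonyl compounds cannot be read, so moving the bromine from the 3-bromophenyl to the 4-bromophenyl group on the sulfonyl sulfur has no readable size, and no order can be drawn among compound 2, compound 3 and compound 4. What compound 4 adds lies in the comparison with the methyl compound: an at least 2.8-fold higher number from compound 1 to compound 4 (0.45 log units; beyond the scatter), a floor that clears the scatter, whereas the floor of an at least 1.9-fold higher number from compound 1 to compound 3 (0.29 log units; that floor lies within the scatter) did not, so a sulfonyl group in place of methyl on the aromatic nitrogen is now shown, for the 4-bromophenyl case, to need more compound in this assay.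

On these data alone, how far the three sulfonyl compounds lie beyond their limits remains open, and so does whether the bromine position matters at all. As far as these compounds go, it is also open whether an amine or a carboxylic acid on the phenyl ring of the sulfonyl group, or a plain hydrogen on the aromatic nitrogen, would give a number rather than a limit.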